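The compounds below may be only part of what the source reports. "The series", "measured", "known", "first", "only" and "open" are said of these compounds alone.

Compound 1 `O=C(Nc1cccc(Cl)c1)N[C@H]1CC[C@H](Oc2ccc(F)cc2)CC1`: 5900 nM
Compound 2 `O=C(Nc1cccc(C(F)(F)F)c1)N[C@H]1CC[C@H](Oc2cccc(F)c2)CC1`: 2400 nM
Compound 3 `O=C(Nc1cccc(C(F)(F)F)c1)N[C@H]1CC[C@@H](Oc2ccc(F)cc2)CC1`: 2600 nM

These three compounds share a common core and were tested in a functional assay on CRL2813 cells (Homo sapiens) for cytotoxicity, read by sulforhodamine B assay, with a stated time of 5 days; a higher number here means a weaker inhibitor, a lower number a stronger inhibitor. Compound 1 has the highest number of the three, so it is the weakest inhibitor in this set. The nearest of the other two is compound 3, whose number is lower by a margin beyond the usual scatter, and the furthest is compound 2, also lower by a margin beyond the scatter. Both compound 2 and compound 3 carry a trifluoromethyl group on the phenyl ring attached to the urea nitrogen, where compound 1 carries a chlorine.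

The next compound, compound 4 `O=C(Nc1ccc(I)cc1)N[C@H]1CC[C@H](Oc2ccc(F)cc2)CC1`, has not yet been measured in this assay. It differs from compound 1 in one place only: 4-iodophenyl in place of 3-chlorophenyl on an amide-type nitrogen. Among the measured compounds shown here, no measured pair shows this particular change, so any expectation rests on the three values above. Because compound 1 gives 5900 nM and the two other substitutions on that ring gave lower numbers, compound 4 is expected to land close to compound 1, with the step estimated as a 1.3-fold lower number from compound 1 to compound 4 (0.12 log units; within the scatter), small and within or just beyond the scatter. The estimated value for compound 4 is 4500 nM, in a range from 1500 nM to 14000 nM.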

Compound 4, half-maximal inhibitory concentration: 10200 nM
For compound 4 the middle estimate is 2.3-fold (0.36 log units) below the measured one; low and high end bracket the measured number.
By their numbers in this assay, from the lowest: compounds 2 and 3 (each within the scatter of the next); then compounds 1 and 4 (each within the scatter of the next).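

In this assay, putting 4-iodophenyl in place of 3-chlorophenyl on the amide-type nitrogen gives a 1.7-fold higher number from compound 1 to compound 4 (0.24 log units; within the scatter), so compound 1 and compound 4 cannot be told apart in this cell test. Among the compounds shown here, this is the first direct comparison in the set between two compounds that differ in one place only, and it shows that this swap on the urea's aryl ring leaves the reading within ordinary repeat variation, even though both the halogen and its numbered ring position change at once. No measurement at hand offers any explanation for this result.

For the compounds shown here, the single pair cannot separate the change of halogen from the change of ring position, and 3-iodophenyl or 4-chlorophenyl on the same nitrogen would be needed to pull those two apart. Also open, from the compounds shown here alone, is whether an unsubstituted phenyl, or a phenyl ring carrying an amine or a carboxylic acid instead of a halogen, would stay within the scatter of compound 1 on the shared core.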